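Pyridin-3-yl in place of 2-methylphenyl on the dienone chain

The source may report more compounds than this note shows. Statements on the series, on what has been measured and on what is new or still open speak of the compounds shown alone.

compound 1 `CC1=C(/C=C/C(=O)/C=C/c2ccc(F)cc2)C(C)(C)CCC1` — in a functional assay on PC-3 cells (Homo sapiens) for cytotoxicity, read by sulforhodamine B assay, with a stated time of 48 h (on this read-out lower numbers stand for stronger inhibition and higher numbers for weaker inhibition), compound 1 gives 8200 nM
compound 2 `CC1=C(/C=C/C(=O)/C=C/c2ccccc2Br)C(C)(C)CCC1` — in this assay compound 2 gives 11400 nM
compound 3 `CC1=C(/C=C/C(=O)/C=C/c2ccccc2C)C(C)(C)CCC1` — in this assay compound 3 gives 44100 nM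

Compound 3 stands highest of the three numbers: from compound 1 it lies a 5.4-fold higher number from compound 1 to compound 3 (0.73 log units; beyond the scatter) and from compound 2 a 3.9-fold higher number from compound 2 to compound 3 (0.59 log units; beyond the scatter), while a 1.4-fold higher number from compound 1 to compound 2 (0.14 log units; within the scatter) stays within the scatter. Compound 4 `CC1=C(/C=C/C(=O)/C=C/c2cccnc2)C(C)(C)CCC1` differs from compound 3 by pyridin-3-yl in place of 2-methylphenyl on a double-bonded chain carbon bound to a double-bonded chain carbon. Among the measured compounds shown here, no measured step exchanges a phenyl ring for a pyridin-3-yl ring, so only the two steps ending at compound 3 bear on this change; both are modest, and both leave compound 3 at the high end. A modest step back toward the numbers of compound 1 and compound 2 is therefore expected in this assay, though its size is uncertain. Compound 4 is estimated at 15000 nM, with a range from 5000 nM to 45000 nM. That estimate means an expected 2.9-fold lower number from compound 3 to compound 4 (0.47 log units; beyond the scatter).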

Compound 4, half-maximal inhibitory concentration: 10200 nM
The estimate for compound 4 lay 1.5-fold (0.17 log units) above the measured number, within the range that was stated.
By their numbers in this assay, from the lowest: compounds 1, 4 and 2 (each within the scatter of the next); then compound 3.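

In this assay, pyridin-3-yl in place of 2-methylphenyl on this chain carbon brings the number down beyond the scatter (a 4.3-fold lower number from compound 3 to compound 4 (0.64 log units; beyond the scatter)). Compound 4 cannot be told apart from the two phenyl compounds with a halogen (a 1.1-fold lower number from compound 2 to compound 4 (0.05 log units; within the scatter); a 1.2-fold higher number from compound 1 to compound 4 (0.09 log units; within the scatter)), so among these four rings only the 2-methylphenyl of compound 3 stands apart. Nothing given here accounts for this difference. On these data alone, whether pyridin-2-yl or pyridin-4-yl would match pyridin-3-yl at this place remains open. So does the outcome with an aminophenyl or carboxyphenyl ring.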